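The source may hold more compounds than are shown below. What is called first, only, known or untested is meant among the compounds shown, and "the series" means these compounds.

Compound 3 `COc1cc(N(Cc2ccc(Cl)cc2)C(=O)CSC(=S)N2CCN(C(=O)OC(C)(C)C)CC2)cc(OC)c1OC` gives the highest number of the three measured compounds in a functional assay on MGC-803 cells (Homo sapiens) for inhibition, read by CCK-8 assay, with a stated time of 48 h (on this read-out lower numbers stand for stronger inhibition and higher numbers for weaker inhibition), at 12900 nM. Going by the values given here, compound 1 `COc1ccc(CN(C(=O)CSC(=S)N2CCN(C(C)=O)CC2)c2cc(OC)c(OC)c(OC)c2)cc1` gives 480 nM, and compound 2 `COc1ccc(CN(C(=O)CSC(=S)N2CCc3ccccc3C2)c2cc(OC)c(OC)c(OC)c2)cc1` gives 5940 nM; the only single-point step measured, a 12-fold higher number from compound 1 to compound 2 (1.09 log units; beyond the scatter), concerns the group on the thiocarbonyl carbon. Compound 4 `COc1ccc(CN(C(=O)CSC(=S)N2CCN(C(=O)OC(C)(C)C)CC2)c2cc(OC)c(OC)c(OC)c2)cc1O` differs from compound 3 in the group on the saturated chain carbon bound to the amide-type nitrogen: 3-hydroxy-4-methoxyphenyl in place of 4-chlorophenyl on a saturated chain carbon bound to an amide-type nitrogen. Among the compounds with values here, no measured step covers this change, and compounds 1 and 3 differ in two places, so their values alone cannot separate the benzyl change from the other. The step from compound 3 to compound 4 is therefore expected to be small, estimated as a 2.2-fold lower number from compound 3 to compound 4 (0.33 log units; beyond the scatter), toward a lower number. Compound 4 is estimated at 6000 nM, within 1800 nM to 20000 nM.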

Compound 4, half-maximal inhibitory concentration: 82 nM
Beside the measured number, compound 4's estimate is 73-fold (1.86 log units) above it; measured number below the stated range.
By their numbers in this assay, from the lowest: compound 4; then compound 1; then compound 2; then compound 3.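

In this assay, the group on a saturated chain carbon bound to an amide-type nitrogen proves decisive: 3-hydroxy-4-methoxyphenyl in place of 4-chlorophenyl gives a 160-fold lower number from compound 3 to compound 4 (2.20 log units; beyond the scatter). The group on the thiocarbonyl carbon is the same in both compounds, so that group does not by itself fix a high number. Nothing available explains why this change has such a large effect. Going by these compounds, the change swaps the whole aryl group, so the separate contributions of the hydroxyl, the methoxy and the lost chlorine remain unknown. On these data alone, whether an amine or a carboxylic acid on that ring would serve equally also stays open.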